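The compounds below may be only part of what the source reports. "The series", "measured", "known", "first", "only" and "open" are said of these compounds alone.

Compound 1 `C/C(=N\NC(=O)COc1cccc2ccccc12)c1ccc(C#N)cc1Br` gives 3.61 in a physicochemical assay for lipophilicity, measured as octanol-water partition (a higher number here means a more lipophilic compound, a lower number a more polar compound), the lowest of the three numbers. Compound 2 `O=C(COc1cccc2ccccc12)N/N=C/c1cccc(O)c1` gives 3.73 in this assay, a number within the scatter of compound 1, while compound 3 `O=C(COc1cccc2ccccc12)N/N=C/c1ccccc1` gives 4.02 in this assay, a number beyond it. Going by the values given here, the only measured single step, a number 0.29 log units higher from compound 2 to compound 3 (within the scatter), is itself within the scatter. Compound 4 `C/C(=N\NC(=O)COc1cccc2ccccc12)c1ccccc1` carries phenyl in place of 2-bromo-4-cyanophenyl on a carbon with a double bond to nitrogen. Among the compounds with values here, that measured step bears on this only loosely: both changes remove a group counted with one hydrogen-bond acceptor, but here a bromine leaves as well, which no measured pair covers. A moderate upward step is therefore expected, a number 0.19 log units higher from compound 1 to compound 4 (within the scatter), with wide uncertainty. Compound 4 is estimated at 3.8, between 3.3 and 4.3.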

Compound 4, partition coefficient: 3.65
For compound 4 the middle estimate is 0.15 log units above the measured one; low and high end bracket the measured number.
By their numbers in this assay, from the lowest: compounds 1, 4, 2 and 3 (each within the scatter of the next, the first and the last beyond it).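

In this assay, phenyl in place of 2-bromo-4-cyanophenyl on a carbon with a double bond to nitrogen gives a number 0.04 log units higher from compound 1 to compound 4 (within the scatter). Going by these compounds alone, this is the first step read at this position, and going from 9 heavy atoms to 6, with the bromine and the nitrile both gone, leaves the two compounds within the scatter. Nothing available accounts for this result.

Whether the bromine and the nitrile each matter little or offset each other stays open, with no phenyl carrying only one of them among the compounds shown. How an amine or a carboxylic acid would read at this place is also unknown.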